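The source may hold more compounds than are shown below. What is called first, only, known or untested is meant among the compounds shown, and "the series" means these compounds.

In a functional assay on the whole organism for inhibition, with Lemna aequinoctialis as the target, tested at 100 ug/mL (on this read-out lower numbers stand for less inhibition of growth and higher numbers for more inhibition of growth at the one concentration tested), compound 1 `C=CCNC(=S)N/N=C1\C(=O)Nc2ccc([N+](=O)[O-])cc21`, which carries allyl on an amide-type nitrogen of the shared core, gives 35%. With 3-methylphenyl on that nitrogen, compound 2 `Cc1cccc(NC(=S)N/N=C2\C(=O)Nc3ccc([N+](=O)[O-])cc32)c1` gives 20%, and with 4-methylphenyl, compound 3 `Cc1ccc(NC(=S)N/N=C2\C(=O)Nc3ccc([N+](=O)[O-])cc32)cc1` gives 20%. Compound 3 thus stands level with compound 2, and together they hold the lowest number of the three.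

The next compound, compound 4 `COc1ccc(NC(=S)N/N=C2\C(=O)Nc3ccc([N+](=O)[O-])cc32)cc1`, keeps all of compound 3 except for one group, with methoxy in place of methyl on an aromatic carbon. This turns 4-methylphenyl into 4-methoxyphenyl. Within the data shown here, no measured pair makes this exact swap, so the evidence is indirect. Replacing allyl with an aryl group gave modest steps, a number 15 percentage points lower from compound 1 to compound 2 (beyond the scatter) and a number 15 percentage points lower from compound 1 to compound 3 (beyond the scatter), but those changes replaced the whole group. The closer comparison is a small edit within the aryl group, 3-methylphenyl to 4-methylphenyl, which gave no change at the digits printed from compound 2 to compound 3 (within the scatter). A similarly small edit is therefore expected to produce no step beyond the scatter in this assay, with either direction possible. The estimated step is no change at the digits printed from compound 3 to compound 4 (within the scatter). For compound 4 the expected value is 20%, with an estimated range of 10% to 35%.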

Compound 4, percent growth inhibition at one concentration: 15%
Compound 4: the middle estimate sits 5 percentage points above what was measured; low and high end bracket the measured number.
By their numbers in this assay, from the lowest: compounds 4, 2 and 3 (each within the scatter of the next); then compound 1.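

In this assay, among these compounds, methoxy in place of methyl on an aromatic carbon, para to a large group, gives a number 5 percentage points lower from compound 3 to compound 4 (within the scatter) and so tests a new kind of edit: the earlier compounds changed only the whole group or the place of a methyl, whereas here the group on the ring itself changes. Measured against the other aryl compound, 4-methoxyphenyl gives a number 5 percentage points lower from compound 2 to compound 4 (within the scatter) and against allyl it gives a number 20 percentage points lower from compound 1 to compound 4 (beyond the scatter), so compounds 2, 3 and 4 lie within the scatter of one another, while each lies beyond the scatter from compound 1. Nothing measured here offers an explanation for these numbers.

From the compounds shown here alone, it remains open whether a more different group at this ring position, such as an amine, a carboxylic acid or a chlorine atom, would move the number beyond the scatter. Going by these compounds, it is also open whether a longer chain in place of allyl on the nitrogen would give more growth inhibition than compound 1 or whether the allyl group is unusual among non-aromatic groups there.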